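Solubility of Three Measured Compounds and One Awaiting Measurement

The compounds below may be only part of what the source reports. "The series", "measured", "known", "first", "only" and "open" are said of these compounds alone.

Of the compounds shown here, three have so far been measured in a physicochemical assay for solubility, in phosphate buffer, measured as kinetic solubility, with a stated time of 1 h, at pH 7.4; on this read-out higher numbers stand for higher solubility and lower numbers for lower solubility. Compound 1 `Cc1cc(C)cc(NC(=O)COc2cc(C)nc3ccc(Cl)cc23)c1` gives 8000 nM. Compound 2 `COc1ccc2nc(C)cc(OCc3ccc4ccccc4n3)c2c1` gives 21000 nM, and compound 3 `COc1ccc2nc(C)cc(OCC(=O)Nc3cc(C)ccc3OC)c2c1` gives 9500 nM. Among these three numbers compound 3 stands second highest; its value and that of compound 1 lie within the scatter of each other, whereas compound 2 shows a higher number that lies beyond the scatter. For the measured compounds named here, no two of the measured compounds differ from one another in only one place, so no measured step is available to guide a prediction.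

Compound 4 `COc1ccc2nc(C)cc(OCC(=O)Nc3ccncc3)c2c1` has not yet been measured in this assay. It differs from compound 3 in a single place: pyridin-4-yl in place of 2-methoxy-5-methylphenyl on an amide-type nitrogen. Going by the values given here, with no measured step to draw on, the expectation rests on the change alone: the step of a 2.6-fold higher number from compound 3 to compound 4 (0.42 log units; beyond the scatter) is expected to be a moderate rise, beyond the scatter but not large. Compound 4 is therefore estimated at 25000 nM, within a range from 8000 nM to 80000 nM.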

Compound 4, solubility: 91500 nM
Compound 4: middle estimate off by 3.7-fold (0.56 log units), on the low side, outside the stated range (above it).
By their numbers in this assay, from the lowest: compounds 1 and 3 (each within the scatter of the next); then compound 2; then compound 4.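

For the compounds shown here, replacing 2-methoxy-5-methylphenyl with pyridin-4-yl on an amide-type nitrogen gives, in this assay, a 9.6-fold higher number from compound 3 to compound 4 (0.98 log units; beyond the scatter), the first measured step in this set. It shows that the number in this read-out can move well beyond the scatter through a change at this one position, while the rest of the structure stays the same. The change swaps a carbon-only aromatic ring of 9 heavy atoms, counting its substituents, for a six-membered aromatic ring with 1 hetero atom and 6 heavy atoms, and nothing measured here explains the size of the step.

This single step changes the ring atoms and removes the methoxy and methyl groups together, so it does not separate their contributions. From the compounds shown here alone, how a plain phenyl or a morpholine at this position would compare remains open.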